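The source may report more compounds than this note shows. Statements on the series, on what has been measured and on what is new or still open speak of the compounds shown alone.

In a functional assay on L02 cells (Homo sapiens) for inhibition (a lower number here means a stronger inhibitor, a higher number a weaker inhibitor), compound 3 `CN(C(=O)CC(CC(=O)NCCN1CCCC1)c1ccccc1)C1Cc2ccccc2C1` gives no number. Its reading of > 100000 nM is a limit of the assay. Compound 4 `CN(C(=O)CC(CC(=O)NCCN1CCCC1)c1ccc(Cl)cc1)C1Cc2ccccc2C1` differs from it by one substitution, phenyl to 4-chlorophenyl, which is chloro in place of hydrogen on an aromatic carbon. Within the data shown here, no measured step isolates this change. The closest evidence comes from two compounds that already carry the 4-chlorophenyl group: compound 1 `O=C(CC(CC(=O)NC1Cc2ccccc2C1)c1ccc(Cl)cc1)NCCN1CCCC1` gives 89400 nM and compound 2 `CCN(C(=O)CC(CC(=O)NCCN1CCCC1)c1ccc(Cl)cc1)C1Cc2ccccc2C1` gives 54200 nM. Their step, a 1.6-fold lower number from compound 1 to compound 2 (0.22 log units; within the scatter), stays within the scatter. Compound 4 is therefore expected to read close to these two, as a modestly stronger inhibitor than compound 3. The expected step is an at least 1.4-fold lower number from compound 3 to compound 4 (0.15 log units; that floor lies within the scatter). The estimated value for compound 4 is 70000 nM, with an expected range from 35000 nM to 100000 nM.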

Compound 4, half-maximal inhibitory concentration: 81500 nM
Compound 4: middle estimate off by 1.2-fold (0.07 log units), on the low side; measured number inside the range.
By their numbers in this assay, from the lowest: compounds 2, 4 and 1 (each within the scatter of the next). At a limit, above all of these: compound 3.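

The step of an at least 1.2-fold lower number from compound 3 to compound 4 (0.08 log units; that floor lies within the scatter) gives the chloro change a reading of its own, but only as a floor. In this assay compound 3 stands at a limit, not a number: the limit of > 100000 nM in this assay, at which 1 of the 4 values shown sits.

The steps of a 1.5-fold higher number from compound 2 to compound 4 (0.18 log units; within the scatter) and a 1.1-fold lower number from compound 1 to compound 4 (0.04 log units; within the scatter) show that, with the 4-chlorophenyl group present, hydrogen, methyl and ethyl on the amide nitrogen remain within the scatter of one another. Still open, going by these compounds, is whether fluoro, methoxy or an amine in place of the chloro, or a longer chain on that nitrogen, would give a step beyond the scatter.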